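The compounds below may be only part of what the source reports. "The series", "measured", "known", "first", "only" and "open" are said of these compounds alone.

Measured in the series:
compound 1 `COc1ccc(CN[C@@H]2CO[C@H](C(c3ccccc3)c3ccccc3)C[C@H]2O)cc1O` — 30.2 nM
compound 2 `COc1ccc(CN[C@@H]2CO[C@H](C(c3ccccc3)c3ccccc3)C[C@H]2O)cn1` — 38.1 nM
compound 3 `c1ccc(C(c2ccccc2)[C@@H]2CC[C@H](NCc3ccc4occc4c3)CO2)cc1` — 25.2 nM

All three were run in an assay on Cerebral cortex for inhibition of Norepinephrine transporter (Rattus norvegicus); on this read-out lower numbers stand for stronger inhibition and higher numbers for weaker inhibition. Going by the values given here, compound 1 gives 30.2 nM and compound 2 gives 38.1 nM; the one single-site step among the measured pairs is a 1.3-fold higher number from compound 1 to compound 2 (0.10 log units; within the scatter). Compound 3 gives 25.2 nM, the lowest of the three numbers, but its gaps to compound 1 and to compound 2 are both within the scatter, so no order among the three can be read from these values.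

Compound 4 `O[C@@H]1C[C@@H](C(c2ccccc2)c2ccccc2)OC[C@H]1NCc1ccc2occc2c1` is the next member. It differs from compound 3 by hydroxy in place of hydrogen on a saturated ring carbon, the hydroxy entering on a saturated ring carbon of the six-membered non-aromatic ring with one oxygen, next to the ring atom that bears a large group and three ring bonds from the ring oxygen. Among the compounds with values here, no measured pair differs by this change alone. What does bear on it: compound 1 and compound 2 both carry this hydroxy on the same core, compound 3 does not, and all three numbers in this assay sit within the scatter of one another. The hydroxy thus gives no sign of moving the number on its own, and the expected step of a 1.1-fold higher number from compound 3 to compound 4 (0.03 log units; within the scatter) is none beyond the scatter. Compound 4 is therefore estimated at 27 nM, with a range of 9 nM to 80 nM.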

Compound 4, inhibition constant: 33.6 nM
The estimate for compound 4 lay 1.2-fold (0.09 log units) below the measured number, within the range that was stated.
By their numbers in this assay, from the lowest: compounds 3, 1, 4 and 2 (each within the scatter of the next).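

The hydroxy now has a direct pair: in this assay the hydroxy in place of hydrogen on a saturated ring carbon of the six-membered non-aromatic ring with 1 oxygen gives a 1.3-fold higher number from compound 3 to compound 4 (0.12 log units; within the scatter) as its reading, so with 1-benzofuran-5-yl on the chain carbon bound to the amine nitrogen, this change produces no step beyond the scatter. With the hydroxy held in place, the group on that chain carbon can also be compared across three members: 1-benzofuran-5-yl in place of 6-methoxypyridin-3-yl gives a 1.1-fold lower number from compound 2 to compound 4 (0.05 log units; within the scatter) as its reading, and 1-benzofuran-5-yl in place of 3-hydroxy-4-methoxyphenyl gives a 1.1-fold higher number from compound 1 to compound 4 (0.05 log units; within the scatter) as its reading, so these three groups cannot be put in order. No supporting evidence bears on these steps.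

The hydroxy step rests on one pair, leaving open whether it would also stay within the scatter with 6-methoxypyridin-3-yl or 3-hydroxy-4-methoxyphenyl on the chain carbon. Also open, going by these compounds, is how an amine, a methoxy or a carboxylic acid on the same saturated ring carbon would read.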